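The source may hold more compounds than are shown below. What is called first, only, known or untested is meant among the compounds shown, and "the series" means these compounds.

Compounds measured so far in an ADME assay (liver) for metabolic stability, with Liver microsome (Rattus norvegicus) as the target, using microsomes and NADPH, with a stated time of 30 min, tested at 1 uM (a higher number here means faster removal of the compound, a lower number slower removal), are these:

- compound 1 `CC(C)(O)C#Cc1cc(C(O)(C(F)(F)F)C(F)(F)F)cnc1N1CCN(S(=O)(=O)c2ccc(N)nc2)CC1` gives 16 mL.min-1.g-1 in this series
- compound 2 `CC(C)n1cc(-c2cc(C(O)(C(F)(F)F)C(F)(F)F)cnc2N2CCN(S(=O)(=O)c3ccc(N)nc3)CC2)cn1` gives 198 mL.min-1.g-1 in this series

Compound 2 holds the higher of the two numbers (198 mL.min-1.g-1), and it stands well clear of compound 1. The next compound is compound 3 `CC(C)(C)n1cc(-c2cc(C(O)(C(F)(F)F)C(F)(F)F)cnc2N2CCN(S(=O)(=O)c3ccc(N)nc3)CC2)cn1` which departs from compound 2 as follows: methyl in place of hydrogen on a saturated chain carbon bound to an aromatic nitrogen and two saturated chain carbons so that isopropyl becomes tert-butyl. Among the measured compounds shown here, only one measured step bears on this, and only loosely (a 12-fold higher number from compound 1 to compound 2 (1.09 log units; beyond the scatter)). It is large and beyond the scatter, and it came with 1-isopropyl-1H-pyrazol-4-yl in place of 3-hydroxy-3-methylbut-1-yn-1-yl on an aromatic carbon. That step exchanged a whole group, whereas the present change adds one methyl. For the measured compounds named here, no measured step shows methyl in place of hydrogen, so the data give no firm direction. Compound 3 is therefore expected to stay near compound 2 (198 mL.min-1.g-1) in this assay with no step beyond the scatter. The expected step is small (a 1.2-fold lower number from compound 2 to compound 3 (0.07 log units; within the scatter)). The estimate for compound 3 is 170 mL.min-1.g-1 (expected range 75 mL.min-1.g-1 to 380 mL.min-1.g-1).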

Compound 3, intrinsic clearance in microsomes: 459 mL.min-1.g-1
Beside the measured number, compound 3's estimate is 2.7-fold (0.43 log units) below it; measured number outside the range, above it.
By their numbers in this assay, from the lowest: compound 1; then compound 2; then compound 3.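

In this assay, among the compounds shown here, the step from isopropyl to tert-butyl gives a 2.3-fold higher number from compound 2 to compound 3 (0.37 log units; beyond the scatter) and is the first measured case of methyl in place of hydrogen; it shows that this one added carbon, on a saturated chain carbon bound to an aromatic nitrogen and two saturated chain carbons, moves the number beyond the scatter. The earlier exchange of a whole group could not show that the outer end of the 1-isopropyl-1H-pyrazol-4-yl group matters on its own, whereas the replacement of 3-hydroxy-3-methylbut-1-yn-1-yl by 1-(tert-butyl)-1H-pyrazol-4-yl now gives a 29-fold higher number from compound 1 to compound 3 (1.46 log units; beyond the scatter) and so runs the same way as the isopropyl exchange but further. Nothing available explains why the added methyl raises the number.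

The compounds shown leave open whether a smaller group such as methyl or a plain hydrogen in place of isopropyl would lower the number, or whether the rise continues with a longer chain. They also leave open whether a hydroxyl-bearing chain or a carboxylic acid at this place would bring the number back towards that of compound 1.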